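Replacing a Cyclopropyl Chain End with a Cyclopentenyl Group

The source may report more compounds than this note shows. Statements on the series, on what has been measured and on what is new or still open speak of the compounds shown alone.

Measured in a functional assay on the whole organism with Rattus norvegicus as the target; a higher number here means that more compound is needed for the effect, a lower number that less compound is needed:
- compound 1 `COC(=O)CC/C=C\CC[C@H]1C(=O)C[C@@H](O)[C@@H]1/C=C/CC(C)(O)CCC1CCCC1`: 1.31 mg/kg
- compound 2 `COC(=O)CC/C=C\CC[C@H]1C(=O)C[C@@H](O)[C@@H]1/C=C/CC(C)(O)CCC1CC1`: 0.273 mg/kg

Of these two, compound 2 has the lower number, so less of it is needed for the effect. The next compound, compound 3 `COC(=O)CC/C=C\CC[C@H]1C(=O)C[C@@H](O)[C@@H]1/C=C/C[C@@](C)(O)C#CC1=CCCC1`, keeps the shared core but changes the side chain: 3-(cyclopent-1-en-1-yl)-1-hydroxy-1-methylprop-2-yn-1-yl in place of 3-cyclopropyl-1-hydroxy-1-methylpropyl on a saturated chain carbon bound to a double-bonded chain carbon. The change lies on a saturated chain carbon bound to a double-bonded chain carbon.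

Among the compounds with values here, only one measured step bears on this. It is a 4.8-fold lower number from compound 1 to compound 2 (0.68 log units; beyond the scatter), where cyclopropyl replaced cyclopentyl. Compound 3 again carries a five-membered ring, which points towards a higher number. That step is a loose guide, however. Within the data shown here, the ring in compound 3 holds a double bond, the chain holds a triple bond, and no measured compound shows what either does. A rise smaller than the measured step therefore seems the fairest guess, and the expected step is a 2.2-fold higher number from compound 2 to compound 3 (0.34 log units; beyond the scatter). In this assay, compound 3 is estimated at 0.6 mg/kg, with an expected range of 0.12 mg/kg to 3 mg/kg.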

Compound 3, dose for half-maximal effect: > 3.16 mg/kg
Compound 3: no number, only a limit (the forecaster's own chance of this, stated with the estimate: 5%); at least 5.2-fold (0.72 log units) between middle value and limit.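

In this assay, compound 3 gives no number, only a limit of the assay: the limit of > 3.16 mg/kg in this assay, at which 1 of the 3 values shown sits. Even with that limit, the new side chain on this saturated chain carbon bound to a double-bonded chain carbon gives an at least 11-fold higher number from compound 2 to compound 3 (1.06 log units; beyond the scatter), and compared with the saturated five-membered ring it gives an at least 2.4-fold higher number from compound 1 to compound 3 (0.38 log units; beyond the scatter). Within the data shown here, the earlier pair showed only that the number changes with the ring at the chain end, whereas this result shows that a five-membered ring end can also sit on a chain that needs more compound than the cyclopentyl side chain of compound 1, so a ring of that size does not by itself set the number.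

The change brings in a ring double bond, a chain triple bond and a defined stereocentre all at once, so these compounds cannot show which of them accounts for the rise, and the limit leaves the true size of the step unknown. Also open, on these data alone, is how the chain would behave with a phenyl ring at its end, or with the cyclopropyl ring carried on the same triple bond.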